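Adding a Second Methyl to a Weaker Naphthyl Analogue

This account rests on a few compounds, and the source may have more. Where it says the series, first, only, none or still open, it means among the compounds named here.

Measured so far:
Compound 1, `Cc1ccc2c(O)cc(-c3cccc(Cl)c3)nc2n1`, 41.7 nM
Compound 2, `Cc1cc(C)c2c(O)cc(-c3cccc(Cl)c3)nc2n1`, 224 nM
Compound 3, `Cc1ccc2c(O)cc(-c3ccc4ccccc4c3)nc2n1`, 3800 nM

In a functional assay on NCI-H460 cells (Homo sapiens) for antiproliferative activity (a higher number here means a weaker inhibitor of growth, a lower number a stronger inhibitor of growth), compound 1 gives 41.7 nM. The change methyl in place of hydrogen on an aromatic carbon turns it into compound 2, and the step was a 5.4-fold higher number from compound 1 to compound 2 (0.73 log units; beyond the scatter). Compound 3 carries a different aromatic group on the shared core; the difference between the two cores is not broken down here, and compound 3 gives 3800 nM, the highest of the three numbers. Compound 4, `Cc1cc(C)c2c(O)cc(-c3ccc4ccccc4c3)nc2n1`, is not yet measured; it arises from compound 3 by the change (methyl in place of hydrogen on an aromatic carbon), the same change seen from compound 1 to compound 2. Because that earlier step was a 5.4-fold higher number from compound 1 to compound 2 (0.73 log units; beyond the scatter), a step of similar size and direction is expected, namely a 3.9-fold higher number from compound 3 to compound 4 (0.60 log units; beyond the scatter). Compound 4 is therefore estimated at 15000 nM, between 4000 nM and 60000 nM.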

Compound 4, concentration for 50% growth inhibition: 13200 nM
Compound 4: middle estimate off by 1.1-fold (0.06 log units), on the high side; the measured number falls inside the stated range.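

In this assay the added methyl again gives a 3.5-fold higher number from compound 3 to compound 4 (0.54 log units; beyond the scatter) and so moves the number the same way as it did on the core of compound 1. Two pairs cannot establish a rule for other cores, and they do not show why the methyl weakens growth inhibition. Within this small set, the change carries from one core to the other with the same direction and a similar size: the same change on two cores in this assay, a 5.4-fold higher number (0.73 log units; beyond the scatter) from compound 1 to compound 2 and a 3.5-fold higher number (0.54 log units; beyond the scatter) from compound 3 to compound 4, 1.5-fold (0.19 log units) apart, within the scatter of two such steps

The compounds shown leave open whether an ethyl group, a methoxy group or an amine in the same place would raise the number as methyl does. They also leave open how the methyl would behave with aromatic groups other than the two shown here.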